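This account rests on a few compounds, and the source may have more. Where it says the series, first, only, none or still open, it means among the compounds named here.

Of the compounds shown here, two have been measured in an assay on HEK293 cells for positive allosteric modulation of metabotropic glutamate receptor 3 (Rattus norvegicus), read by thallium flux, with a stated time of 2.5 min; a higher number here means that more compound is needed for the effect, a lower number that less compound is needed. Compound 1 `Cc1c(OCCCCOc2ccc(C(=O)O)cc2Cl)ccc(C(=O)CC2CCCC2)c1O` gives only a limit there, > 10000 nM, so no number is available for it. Within the data shown here, compound 2 `COc1ccc(C(=O)O)cc1OCCCCOc1ccc(C(=O)CC2CCCC2)c(O)c1C` gives 1020 nM in this assay, and this is the only number among the values shown. The other value, that of compound 1, is a limit (the limit of > 10000 nM in this assay, at which 1 of the 2 values shown sits). Among the measured compounds shown here, the single measured step, an at least 9.8-fold lower number from compound 1 to compound 2 (0.99 log units; beyond the scatter), lies beyond the scatter and runs from a limit to a number.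

Compound 3 `Cc1cc(OCCCCOc2ccc(C(=O)CC3CCCC3)c(O)c2C)ccc1C(=O)O` differs from compound 2 in one place: 4-carboxy-3-methylphenyl in place of 5-carboxy-2-methoxyphenyl on an oxygen on a saturated carbon. The entering 4-carboxy-3-methylphenyl shares the 4-carboxy arrangement of the 4-carboxy-2-chlorophenyl of compound 1, whose value is a limit, whereas the 5-carboxy-2-methoxyphenyl of compound 2 is the only pattern that gave a number. On this slim evidence the change is expected to move the number back toward the weaker side, with a real chance that this assay again reports only a limit. The expected step is a 4.4-fold higher number from compound 2 to compound 3 (0.64 log units; beyond the scatter). Compound 3 is therefore estimated at 4500 nM in this assay, between 1200 nM and 15000 nM.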

Compound 3, half-maximal effective concentration: > 10000 nM
Compound 3: no number, only a limit; the forecaster's own chance of this, stated with the estimate: 40%; middle value at least 2.2-fold (0.34 log units) from the limit.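

In this assay, 4-carboxy-3-methylphenyl entering in place of 5-carboxy-2-methoxyphenyl, on an oxygen on a saturated carbon, gives an at least 9.8-fold higher number from compound 2 to compound 3 (0.99 log units; beyond the scatter), so at this place on the shared core a carboxy-bearing phenyl does not by itself keep a measurable number. Among these compounds, compound 1 and compound 3, the two compounds with a 4-carboxy group, both give only a limit in this assay, which leaves compound 2 as the one compound of the three with a number: the limit of > 10000 nM in this assay, at which 2 of the 3 values shown sit. The step from compound 1 to compound 3 joins two limits and cannot be read, so 4-carboxy-2-chlorophenyl and 4-carboxy-3-methylphenyl cannot be ranked against each other.

Compound 2 differs from compound 1 and from compound 3 in both the placing of the carboxy group and the other group on the ring, so the compounds shown do not separate the share of the methoxy from that of the carboxy placing. On these data alone, it also remains open how a 4-carboxy-2-methoxyphenyl or a 5-carboxy-2-chlorophenyl would read at this place, and whether a tetrazole could stand in for the carboxylic acid of compound 2.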